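A few compounds are considered here, and "the series" means these few. Any claim that something is new, unique, unknown or untested is made for them only; others in the source may bear on it.

Among the compounds with values here, the three measured members share one core and differ only in a single group on an aromatic carbon. Compound 1 `CC(=O)c1cccc(OCc2cccc(F)c2)c1` gives 193 nM in an assay on isolated protein for inhibition of Amine oxidase [flavin-containing] B (Homo sapiens), read by Amplex Red, with a stated time of 15 min; a higher number here means a weaker inhibitor, a lower number a stronger inhibitor. Compound 2 `CC(=O)c1cccc(OCc2cccc(Br)c2)c1` gives 96.3 nM in this assay, and compound 3 `CC(=O)c1cccc(OCc2cccc(C)c2)c1` gives 893 nM. On these numbers compound 3 stands highest of the three: the rises in a 4.6-fold higher number from compound 1 to compound 3 (0.67 log units; beyond the scatter) and in a 9.3-fold higher number from compound 2 to compound 3 (0.97 log units; beyond the scatter) are both beyond the scatter, whereas a 2.0-fold lower number from compound 1 to compound 2 (0.30 log units; within the scatter) stays within it, so compounds 1 and 2 are not ordered against each other.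

Compound 4 `CC(=O)c1cccc(OCc2cccc(C(F)(F)F)c2)c1` is the unmeasured member; relative to compound 3 the change is trifluoromethyl in place of methyl on an aromatic carbon. Within the data shown here, no measured step involves a trifluoromethyl group, so the steps that bear on this one are the two in which methyl replaced a halogen, the modest rises in a 4.6-fold higher number from compound 1 to compound 3 (0.67 log units; beyond the scatter) and a 9.3-fold higher number from compound 2 to compound 3 (0.97 log units; beyond the scatter). Read in reverse, taking the methyl away in favour of a group built from one carbon and three fluorines is expected to bring the number back down by a modest amount, with real uncertainty about the size, since the closest comparator is a single fluorine. The expected step is a 3.6-fold lower number from compound 3 to compound 4 (0.55 log units; beyond the scatter). Compound 4 is therefore estimated at 250 nM, with a range from 80 nM to 800 nM.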

Compound 4, half-maximal inhibitory concentration: 21.2 nM
Estimate against measurement, compound 4: 12-fold (1.07 log units) above; the measured number lies below the stated range.
By their numbers in this assay, from the lowest: compound 4; then compounds 2 and 1 (each within the scatter of the next); then compound 3.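

Within the shared core, the single carbon stays in place while its three fluorines replace the hydrogens of the methyl group, and in this assay this gives a 42-fold lower number from compound 3 to compound 4 (1.62 log units; beyond the scatter), the only step in the series printed as large, so this position separates two one-carbon groups very sharply. The earlier compounds shown here left fluoro and bromo unordered and placed methyl highest, which could have been read as halogen against methyl, but trifluoromethyl goes beyond both halogens with a 4.5-fold lower number from compound 2 to compound 4 (0.66 log units; beyond the scatter) and a 9.1-fold lower number from compound 1 to compound 4 (0.96 log units; beyond the scatter), leaving compound 4 with the lowest number of the four. No supporting evidence bears on why this change has such an effect.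

As far as these compounds go, it remains open whether the low number is particular to trifluoromethyl or is shared by other groups at this place, such as a nitrile, a methoxy group, a chloro group or a longer chain such as ethyl. The compounds shown also leave open whether the same order of groups would hold if the acetyl group of the shared core were replaced by an amide or a carboxylic acid.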